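A few compounds are considered here, and "the series" means these few. Any claim that something is new, unique, unknown or untested is made for them only; others in the source may bear on it.

Measured so far in a functional assay on SF-268 cells (Homo sapiens) for cytotoxicity, read by sulforhodamine B assay, with a stated time of 48 h, tested at 10 uM; on this read-out lower numbers stand for a stronger effect and higher numbers for a weaker effect at the one concentration tested:
- compound 1 `COc1cc(C)cc(-c2nn(CC#N)cc2-c2ccc(-c3cccc(C(C)=O)c3)nc2)c1` gives -2%
- compound 2 `Cc1cc(O)cc(-c2nn(CC#N)cc2-c2ccnc(-c3ccc(Oc4ccccc4)cc3)c2)c1` gives -95%
- compound 3 `COc1cc(C)cc(-c2nn(CC#N)cc2-c2ccnc(-c3ccc(N(C)C)cc3)c2)c1` gives -32%

Among these three numbers compound 3 stands second highest. Its nearest neighbour is compound 1, whose number lies higher by a gap beyond the usual scatter; compound 2 lies furthest away, with a number much lower, again beyond the scatter. Compound 3 therefore shows a clearer effect than compound 1 but a much weaker one than compound 2.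

Compound 4 `Cc1cc(O)cc(-c2nn(CC#N)cc2-c2ccnc(-c3ccc(N(C)C)cc3)c2)c1` has not yet been measured. Compared with compound 3 the change is hydrogen in place of methyl on an oxygen on an aromatic ring, so that the 3-methoxy-5-methylphenyl of compound 3 becomes 3-hydroxy-5-methylphenyl in compound 4, while the rest of the molecule stays as it is.

Among the compounds with values here, no measured pair shows this exact change on its own. Compound 2 also carries a hydroxy on that ring and gives a very low number, but it differs from compound 4 in another part too, so it can only hint at the direction. The step from compound 3 to compound 4 in this assay is expected to be a number 23 percentage points lower from compound 3 to compound 4 (beyond the scatter), towards a lower number and beyond the scatter, with wide uncertainty. Compound 4 is estimated at -55%, within a range from -90% to -15%.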

Compound 4, a percentage reported as activity, at one concentration (the size of the read-out at that concentration, not a potency): -58%
The estimate for compound 4 lay 3 percentage points above the measured number, and the stated range covers the measured number.
By their numbers in this assay, from the lowest: compound 2; then compound 4; then compound 3; then compound 1.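

In this assay, within the data shown here, removing the methyl from the oxygen on the aromatic ring, so that methoxy becomes hydroxy, gives a number 26 percentage points lower from compound 3 to compound 4 (beyond the scatter), which is the first clean evidence that this one small change alters the read-out on its own: the lower number stands for a stronger effect. Compound 4 also links to compound 2, and with the hydroxy held constant, placing dimethylamino where phenoxy stood on an aromatic carbon gives a number 37 percentage points higher from compound 2 to compound 4 (beyond the scatter), so the hydroxy alone does not set the level of the effect and the group at the far end of the molecule matters as well. No measurement shown here explains either step.

Among these compounds, there is only one methoxy-to-hydroxy pair, so it remains open whether the same step would appear with phenoxy at the far end of the molecule. As far as these compounds go, it also remains open how far the result depends on the hydroxy itself, which an amino group, a fluorine or an ethoxy group at the same place on the ring could help to test.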